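The source may report more compounds than this note shows. Statements on the series, on what has been measured and on what is new or still open speak of the compounds shown alone.

In a functional assay on EKVX cells (Homo sapiens) for inhibition, read by sulforhodamine B assay, with a stated time of 48 h, tested at 10 uM (a lower number here means a stronger effect, a higher number a weaker effect of the compound at the concentration tested), compound 1 `COc1cc2cc(Oc3ccc(NC(=O)Nc4ccccc4)cc3)c(C)nc2cc1OC` gives 63.4% and compound 2 `COc1cc2cc(Oc3ccc(NC(=O)Nc4ccc(C)cc4)cc3)c(C)nc2cc1OC` gives 107%, while compound 3 `COc1cc2cc(Oc3ccc(NC(=O)Nc4ccc(Cl)c(C(F)(F)F)c4)cc3)c(C)nc2cc1OC` gives 8.83%, the lowest of the three; the step of a number 54.6 percentage points lower from compound 1 to compound 3 (beyond the scatter) is the nearer one and the step of a number 98.2 percentage points lower from compound 2 to compound 3 (beyond the scatter) the wider. Both steps bring in the 4-chloro-3-(trifluoromethyl)phenyl group on the amide-type nitrogen, and both are large and downward. Compound 4 `COc1cc2cc(Oc3ccc(NC(=O)Nc4ccc(Cl)c(Cl)c4)cc3)c(C)nc2cc1OC` differs from compound 3 by chloro in place of trifluoromethyl on an aromatic carbon. For the measured compounds named here, no measured pair exchanges these two groups, so the data do not fix the size of this change; the two large steps into compound 3 are the only guide. Compound 4 is expected to stay close to compound 3, with a step of a number 6.2 percentage points higher from compound 3 to compound 4 (within the scatter), a slight rise probably within the scatter. The estimate for compound 4 is 15%, ranging from 3% to 45%.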

Compound 4, a percentage reported as activity, at one concentration (the size of the read-out at that concentration, not a potency): 21%
Compound 4: the middle estimate sits 6 percentage points below what was measured, within the range that was stated.
By their numbers in this assay, from the lowest: compound 3; then compound 4; then compound 1; then compound 2.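

The direct exchange at this position gives a number 12.2 percentage points higher from compound 3 to compound 4 (beyond the scatter) in this assay, a modest step beyond the scatter, so trifluoromethyl can be replaced by chloro with most of the effect kept. The 3,4-dichlorophenyl group still gives a number 42.4 percentage points lower from compound 1 to compound 4 (beyond the scatter) and a number 86 percentage points lower from compound 2 to compound 4 (beyond the scatter), so both halogen-bearing compounds remain well apart from the phenyl and 4-methylphenyl compounds. Nothing available explains the step between trifluoromethyl and chloro.

Still open, on these data alone, is whether the 4-chloro group alone would suffice, without a second group at this position. Also open, as far as these compounds go, is how a methoxy group, a nitrile or an amine would behave here.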